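Aryl amine swap on the shared core, cytotoxicity notes

A few compounds are considered here, and "the series" means these few. Any claim that something is new, unique, unknown or untested is made for them only; others in the source may bear on it.

For the measured compounds named here, compound 1 `C=C1[C@@H](OC(C)=O)C[C@@H]2[C@](C)(COC=O)[C@H](OC(C)=O)CC[C@@]2(C)[C@@H]1C[C@@H](Nc1ccc(OC)c(OC)c1)C1=CCOC1=O` is the weakest of the three measured members in a functional assay on HT-29 cells (Homo sapiens) for cytotoxicity, read by sulforhodamine B assay (a lower number here means a stronger inhibitor, a higher number a weaker inhibitor), where compound 1 gives 42800 nM. Compound 3 `C=C1[C@@H](OC(C)=O)C[C@@H]2[C@](C)(CO[Si](C)(C)C(C)(C)C)[C@H](OC(C)=O)CC[C@@]2(C)[C@@H]1C/C=C1/C(=O)OC[C@H]1OC(C)=O` sits nearest to it, compound 3 giving 4940 nM, while compound 2 `C=C1[C@@H](OC(C)=O)C[C@@H]2[C@](C)(CO[Si](C)(C)C(C)(C)C)[C@H](OC(C)=O)CC[C@@]2(C)[C@@H]1C[C@@H](Nc1cccc(F)c1)C1=CCOC1=O` lies furthest away, compound 2 giving 4520 nM; both gaps to compound 1 are beyond the scatter. Compound 4 `C=C1[C@@H](OC(C)=O)C[C@@H]2[C@](C)(COC=O)[C@H](OC(C)=O)CC[C@@]2(C)[C@@H]1C[C@@H](Nc1ccc(F)cc1)C1=CCOC1=O` differs from compound 1 by 4-fluorophenyl in place of 3,4-dimethoxyphenyl on an amine nitrogen. Going by the values given here, no measured pair isolates this change, so the step is judged from the standing of compound 1 alone. A move toward lower numbers in this assay, beyond the scatter but short of the gap to compound 2, is expected, as a 2.9-fold lower number from compound 1 to compound 4 (0.46 log units; beyond the scatter). For compound 4 the estimate is 15000 nM, with a range from 5000 nM to 45000 nM.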

Compound 4, half-maximal inhibitory concentration: 20500 nM
Compound 4: the middle estimate sits 1.4-fold (0.14 log units) below what was measured; the range from low to high includes it.
By their numbers in this assay, from the lowest: compounds 2 and 3 (each within the scatter of the next); then compound 4; then compound 1.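

In this assay, for the compounds shown here, this is the first pair to isolate a change on the amine nitrogen: 4-fluorophenyl in place of 3,4-dimethoxyphenyl gives a 2.1-fold lower number from compound 1 to compound 4 (0.32 log units; beyond the scatter). The aryl group at this position therefore affects the cytotoxicity read-out on the shared core, though the step is modest. Nothing available here bears on the reason for this step.

Still open, going by these compounds, is whether the step comes from gaining the fluorine or losing the methoxy groups. Unsubstituted phenyl or 4-methoxyphenyl on the same nitrogen could separate the two.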